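Working notes on three analogues of one shared core

The source may hold more compounds than are shown below. What is called first, only, known or untested is meant among the compounds shown, and "the series" means these compounds.

Measured compounds:
- compound 1 `Oc1nc2nonc2nc1Nc1cccc(S(F)(F)(F)(F)F)c1`: 3700 nM
- compound 2 `CCc1cccc(Nc2nc3nonc3nc2O)c1`: 25200 nM

Both numbers come from an assay on mitochondria from L6 cells (Rattus norvegicus) for activation, with a stated time of 90 min; on this read-out higher numbers stand for an effect only at larger amounts of compound and lower numbers for an effect already at smaller amounts. For the measured compounds named here, compound 2 gives the highest number of the two; its only neighbour is compound 1, and the step of a 6.8-fold higher number from compound 1 to compound 2 (0.83 log units; beyond the scatter) separates them. Compound 3 `Oc1nc2nonc2nc1Nc1cccc(OC(F)(F)F)c1` has not yet been measured. Its difference from compound 2 is trifluoromethoxy in place of ethyl on an aromatic carbon.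

Going by the values given here, only one measured step bears on this change: the step from compound 1 to compound 2, which is modest but beyond the scatter, and which replaced a group holding fluorine and sulfur by ethyl. Among the compounds with values here, compound 3 reverses that direction in part, since trifluoromethoxy again brings fluorine onto the same aromatic carbon, though it is a smaller group than the one in compound 1 and carries one hydrogen-bond acceptor. The expectation is therefore a step toward lower numbers in this assay, of a size below the step from compound 1 to compound 2 but beyond the scatter, so that compound 3 is expected to land between compound 2 and compound 1. The expected step is a 3.6-fold lower number from compound 2 to compound 3 (0.56 log units; beyond the scatter). For compound 3 the estimate is 7000 nM, within 3000 nM to 16000 nM.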

Compound 3, half-maximal effective concentration: 5100 nM
Beside the measured number, compound 3's estimate is 1.4-fold (0.14 log units) above it, and the stated range covers the measured number.
By their numbers in this assay, from the lowest: compounds 1 and 3 (each within the scatter of the next); then compound 2.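

In this assay, a second fluorine-bearing group on the same aromatic carbon now stands against ethyl: the change to trifluoromethoxy gives a 4.9-fold lower number from compound 2 to compound 3 (0.69 log units; beyond the scatter), so the earlier gap to ethyl no longer rests on the group of compound 1 alone. The two fluorine-bearing groups do not separate, with a 1.4-fold higher number from compound 1 to compound 3 (0.14 log units; within the scatter), although they differ in heavy atoms and only trifluoromethoxy carries a hydrogen-bond acceptor; among these three compounds, ethyl alone stands apart, and no compound goes against that grouping. Nothing available explains this grouping or links it to any measured property of the groups.

The compounds shown leave open whether the lower numbers go with the fluorine atoms or with some other feature of the two groups, as ethyl is the only comparison without fluorine; methoxy and trifluoromethyl on the same aromatic carbon would help to separate these readings. As far as these compounds go, it also remains open whether a plain hydrogen there would fall with ethyl or with the two fluorine-bearing groups in this assay, and whether the grouping would hold on another carbon of the ring.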